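Replacing Phenyl with Pyridine: Expected Shift in Unbound Fraction

The compounds below may be only part of what the source reports. "The series", "measured", "known", "first", "only" and "open" are said of these compounds alone.

Compound 1 `Cc1nc2c(s1)CC[C@H]2C(=O)Nc1ccc(C[C@@H]2CC[C@H]([C@H](O)c3ccccc3)N2)cc1` stands lowest of the two compounds measured in an ADME assay on the whole organism (plasma, Rattus norvegicus, strain Sprague-Dawley) for protein binding (on this read-out lower numbers stand for a smaller free fraction and higher numbers for a larger free fraction), where compound 1 gives 0.05. Compound 2 `Nc1nc2c(s1)CC[C@H]2C(=O)Nc1ccc(C[C@@H]2CC[C@H]([C@H](O)c3ccccc3)N2)cc1` differs in one group and gives 0.18, so that a 3.6-fold higher number from compound 1 to compound 2 (0.56 log units; beyond the scatter). Compound 3 `Cc1nc2c(s1)CC[C@H]2C(=O)Nc1ccc(C[C@@H]2CC[C@H]([C@H](O)c3cccnc3)N2)cc1` carries a different change: pyridin-3-yl in place of phenyl on a saturated chain carbon bound to an oxygen on a saturated carbon and a saturated ring carbon. Among the measured compounds shown here, no measured step covers this exchange, since the only known step concerns another group on another ring. For compound 3 a modest rise is nevertheless expected, a 1.8-fold higher number from compound 1 to compound 3 (0.26 log units; within the scatter). Compound 3 is estimated at 0.09, within a range from 0.04 to 0.2.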

Compound 3, unbound fraction: 0.11
Estimate against measurement, compound 3: 1.2-fold (0.09 log units) below; the measured number falls inside the stated range.
By their numbers in this assay, from the lowest: compound 1; then compounds 3 and 2 (each within the scatter of the next).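

In this assay, among the compounds shown here, the earlier compounds showed a change only on another ring, and this result shows that the free fraction also responds at the saturated chain carbon bound to an oxygen. Pyridin-3-yl in place of phenyl gives a 2.2-fold higher number from compound 1 to compound 3 (0.34 log units; beyond the scatter). Nothing here explains why the number moves.

Going by these compounds, whether pyridin-4-yl or a fluorophenyl group in this place would shift the number in the same direction remains open. So does the outcome of combining pyridin-3-yl with the amino group of compound 2 .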